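Swapping the aryl group of compound 2

This account rests on a few compounds, and the source may have more. Where it says the series, first, only, none or still open, it means among the compounds named here.

In a functional assay on KB cells (Homo sapiens) for antiproliferative activity, read by sulforhodamine B assay, with a stated time of 3 days (on this read-out higher numbers stand for an effect only at larger amounts of compound and lower numbers for an effect already at smaller amounts), compound 1 (`CCC1=C(O)c2c(oc(-c3ccc(O)cc3)cc2=O)C(CC)(CC)C1=O`) gives 20.6 uM and compound 2 (`CCC1=C(O)c2c(oc(-c3ccc(OC)c(Cl)c3)cc2=O)C(CC)(CC)C1=O`) gives 24.9 uM on the same scale. Compound 2 thus has a single measured neighbour, compound 1, and the two lie within the scatter of each other, so neither can be ranked.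

The next structure is compound 3 (`CCC1=C(O)c2c(oc(-c3cccc(C)c3C)cc2=O)C(CC)(CC)C1=O`), which keeps the shared core and changes only the aryl group: 2,3-dimethylphenyl in place of 3-chloro-4-methoxyphenyl on an aromatic carbon with 2,3-dimethylphenyl in place of 3-chloro-4-methoxyphenyl on an aromatic carbon. Within the data shown here, the one measured step at this same place is a 1.2-fold higher number from compound 1 to compound 2 (0.08 log units; within the scatter) and it stays within the scatter even though 3-chloro-4-methoxyphenyl replaced 4-hydroxyphenyl there. Among the measured compounds shown here, no measured compound carries 2,3-dimethylphenyl, and a single step is thin evidence, so the range must stay wide. The expected change is a 1.1-fold lower number from compound 2 to compound 3 (0.05 log units; within the scatter) and thus nothing beyond the scatter. Compound 3 is estimated at 22 uM with an expected range of 10 uM to 50 uM in this assay once it is measured.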

Compound 3, concentration for half-maximal effect: 3.1 uM
For compound 3 the middle estimate is 7.1-fold (0.85 log units) above the measured one; measured number below the stated range.
By their numbers in this assay, from the lowest: compound 3; then compounds 1 and 2 (each within the scatter of the next).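

Among these compounds, until now the only step at this aromatic carbon next to the ring oxygen stayed within the scatter, so it could have seemed that the aryl group there made little difference. Compound 3 shows that this position can respond in this assay: the change to 2,3-dimethylphenyl gives an 8.0-fold lower number from compound 2 to compound 3 (0.90 log units; beyond the scatter) and, measured against the other aryl group, a 6.6-fold lower number from compound 1 to compound 3 (0.82 log units; beyond the scatter), so the same result appears from both measured starting points, while 4-hydroxyphenyl and 3-chloro-4-methoxyphenyl cannot be told apart. Nothing in the available data accounts for the size of these steps, and the reason for them remains unknown.

The three compounds do not show whether both methyl groups of 2,3-dimethylphenyl are needed, or whether either one alone, or an unsubstituted phenyl, would give a number as low as that of compound 3. They also leave open how an aryl group carrying an amine or a carboxylic acid, or a longer chain such as propyl in place of the methyl groups, would fall on this read-out.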